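This account rests on a few compounds, and the source may have more. Where it says the series, first, only, none or still open, it means among the compounds named here.

Measured so far in a functional assay on A375P cells (Homo sapiens) for antiproliferative activity, read by MTT assay, with a stated time of 48 h; a higher number here means a weaker inhibitor, a lower number a stronger inhibitor:
compound 1 `CC(=O)Nc1cccc2c(-c3cccc(NC(=O)c4cccc(C(F)(F)F)c4)c3)ccnc12` gives 8000 nM
compound 2 `CC(=O)Nc1cccc2c(-c3cccc(NC(=O)c4cc(Cl)cc(C(F)(F)F)c4)c3)ccnc12` gives 6200 nM

Compound 2 carries the lower of the two numbers in this assay, but the step of a 1.3-fold lower number from compound 1 to compound 2 (0.11 log units; within the scatter) lies within the scatter, so no order between compound 1 and compound 2 is claimed. Compound 3 `CC(=O)Nc1cccc2c(-c3cccc(NC(=O)c4cc(C(F)(F)F)cc(C(F)(F)F)c4)c3)ccnc12` is not yet measured; it differs from compound 2 by trifluoromethyl in place of chloro on an aromatic carbon. Going by the values given here, the one step on hand, a 1.3-fold lower number from compound 1 to compound 2 (0.11 log units; within the scatter), chloro in place of hydrogen, left the number essentially unchanged, and replacing that chloro by trifluoromethyl is expected to behave alike. Compound 3 is therefore estimated at 5500 nM (range 2500 nM to 12000 nM). The expected step of a 1.1-fold lower number from compound 2 to compound 3 (0.05 log units; within the scatter) stays within the scatter.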

Compound 3, half-maximal inhibitory concentration: 1000 nM
Beside the measured number, compound 3's estimate is 5.5-fold (0.74 log units) above it; the whole stated range lies above it.
By their numbers in this assay, from the lowest: compound 3; then compounds 2 and 1 (each within the scatter of the next).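

In this assay, this position proves able to move the number: trifluoromethyl in place of chloro gives a 6.2-fold lower number from compound 2 to compound 3 (0.79 log units; beyond the scatter), whereas chloro in place of hydrogen had stayed within the scatter. Trifluoromethyl in place of hydrogen gives an 8.0-fold lower number from compound 1 to compound 3 (0.90 log units; beyond the scatter), so among the three groups at this position, only trifluoromethyl separates from the others. Nothing on hand accounts for the difference between chloro and trifluoromethyl. Open, as far as these compounds go, is whether a nitrile or a methoxy group at this position would match trifluoromethyl, and how an amine there would read.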